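Two aryl-piperazine amides and an untested dimethylphenyl analogue

The source may hold more compounds than are shown below. What is called first, only, known or untested is meant among the compounds shown, and "the series" means these compounds.

Measured compounds:
compound 1, `Cc1nc(-c2ccccc2F)c(C(=O)N2CCN(c3cc(Cl)cc(Cl)c3)CC2)o1`, 0.177 ug/mL
compound 2, `Cc1nc(-c2ccccc2)c(C(=O)N2CCN(c3cccc(C#N)c3)CC2)o1`, 2.52 ug/mL

The series is compared in a toxicity assay on HUVEC cells (Homo sapiens) for inhibition; a lower number here means a stronger inhibitor of growth, a higher number a weaker inhibitor of growth. Compound 1 gives 0.177 ug/mL, and compound 2 gives 2.52 ug/mL. Among the two numbers, compound 2 stands highest; its nearest neighbour, compound 1, sits well beyond the scatter of repeated measurements, so compound 2 is the weaker growth inhibitor of the pair.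

The next compound is compound 3, `Cc1nc(-c2ccccc2)c(C(=O)N2CCN(c3cccc(C)c3C)CC2)o1`. It differs from compound 2 in one place: 2,3-dimethylphenyl in place of 3-cyanophenyl on an amine nitrogen in a ring

No directly comparable step between measured compounds is available, so the step from compound 2 to compound 3 is estimated from the shown values alone. A moderate lowering of the number is expected, a 2.5-fold lower number from compound 2 to compound 3 (0.40 log units; beyond the scatter), though the two values give little to anchor it. Compound 3 is therefore estimated at 1 ug/mL, with a range from 0.3 ug/mL to 3 ug/mL.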

Compound 3, concentration for 50% growth inhibition: 0.38 ug/mL
Estimate against measurement, compound 3: 2.6-fold (0.42 log units) above; the measured number falls inside the stated range.
By their numbers in this assay, from the lowest: compound 1; then compound 3; then compound 2.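

In this assay, exchanging 3-cyanophenyl for 2,3-dimethylphenyl on an amine nitrogen in a ring gives a 6.6-fold lower number from compound 2 to compound 3 (0.82 log units; beyond the scatter), which shows that this position alone can move the number beyond the scatter while the rest of the molecule stays the same. The earlier pair differed in more than one place, so its gap could not be assigned to this position. No measurement shown explains the step, and the single exchange removes the nitrile and adds both methyl groups at once, so their separate contributions cannot be told apart.

From the compounds shown here alone, it remains open whether a single methyl group, a methoxy group or a chlorine on the phenyl ring would give a step of similar size. Going by these compounds, it is also open whether the same exchange would carry over to the core of compound 1.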